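This account rests on a few compounds, and the source may have more. Where it says the series, first, only, none or still open, it means among the compounds named here.

The series rests on a shared core that differs between its two branches. Compound 1 `CN(C)CCn1c(N)c(-c2nc3ccccc3n2C)c2nc(C#N)c(C#N)nc21` and compound 2 `CCN(CC)CCn1c(N)c(-c2nc3ccccc3n2C)c2nc(C#N)c(C#N)nc21` share one core; compound 3 `CN(C)CCn1c(N)c(-c2nc3cc(Cl)ccc3[nH]2)c2nc(C#N)c(C#N)nc21` and compound 4 `CCN(CC)CCn1c(N)c(-c2nc3cc(Cl)ccc3[nH]2)c2nc(C#N)c(C#N)nc21` share another. How the two cores differ is not broken down here.

In a functional assay on cells (Homo sapiens) for antiproliferative activity, read by MTT assay, with a stated time of 48 h (on this read-out higher numbers stand for weaker inhibition and lower numbers for stronger inhibition), compound 1 gives > 50000 nM, which is a limit of the assay and not a number. In this assay compound 2 gives > 50000 nM, again a limit of the assay. The change between them is diethylamino in place of dimethylamino on a saturated chain carbon, two bonds along the chain from an aromatic nitrogen and its step is a step that the two limits leave unreadable from compound 1 to compound 2. In this assay compound 3 gives > 50000 nM, also a limit of the assay. All three measured values therefore sit at the same point, as shown by the limit of > 50000 nM in this assay, at which 3 of the 3 values shown sit.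

Compound 4 differs from compound 3 by diethylamino in place of dimethylamino on a saturated chain carbon, two bonds along the chain from an aromatic nitrogen, the same kind of change as from compound 1 to compound 2, at the same place. Within the data shown here, since that earlier step could not be read, and since compound 1, compound 2 and compound 3 all sit at the limit of > 50000 nM in this assay, at which 3 of the 3 values shown sit, no measured step gives a direction. The expectation for compound 4 therefore rests on the value of compound 3, > 50000 nM, and on the unreadable earlier step. Compound 4 is expected to show a step that the limit leaves unreadable from compound 3 to compound 4 in this assay, with no usable change. The estimate for compound 4 is 70000 nM, expected to fall between 25000 nM and 200000 nM, most likely again reported as a limit.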

Compound 4, half-maximal inhibitory concentration: > 50000 nM
Compound 4: only a limit was reported; the forecaster's own chance of this, stated with the estimate: 85%; the middle value does not contradict the limit.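

Compound 4, like compound 1, compound 2 and compound 3, sits at a limit of the assay and not at a number, so no new step involving compound 4 can be read in this assay: the limit of > 50000 nM in this assay, at which 4 of the 4 values shown sit.

The compounds shown leave open whether diethylamino in place of dimethylamino, or 5-chloro-1H-benzimidazol-2-yl in place of 1-methyl-1H-benzimidazol-2-yl, changes the result in this assay at all.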